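The source may hold more compounds than are shown below. What is called first, only, known or untested is meant among the compounds shown, and "the series" means these compounds.

Three compounds have been measured in a physicochemical assay for solubility, measured as kinetic solubility, at pH 2; a higher number here means a more soluble compound, a lower number a less soluble compound:

compound 1 `CC(C)/C(=C1\C(=O)NC(=O)N1C)c1ccc(-c2ccc3cccc(F)c3c2)[nH]c1=O` gives 11100 nM
compound 2 `O=C1NC(=O)/C(=C/C(c2ccc(-c3ccc4cccc(F)c4c3)[nH]c2=O)C2CC2)O1` gives 3850 nM
compound 3 `CC(C)C(/C=C1/C(=O)NC(=O)N1C)c1ccc(-c2ccc3cccc(F)c3c2)[nH]c1=O` gives 8300 nM

In this assay compound 2 has the lowest of the three numbers. Its nearest neighbour is compound 3, whose number is higher by a gap beyond the usual scatter, and compound 1 lies further away still, also beyond the scatter. No pair of these compounds differs in one place only, so no single step between measured compounds is at hand; what follows rests on the three values and on the structural change alone.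

Compound 4 `O=C1NC(=O)/C(=C/C(c2ccccc2)c2ccc(-c3ccc4cccc(F)c4c3)[nH]c2=O)O1` has not yet been measured in this assay. It is derived from compound 2 by one change: phenyl in place of cyclopropyl on a saturated chain carbon bound to an aromatic carbon and a double-bonded chain carbon. A three-membered non-aromatic ring of carbon only leaves, a six-membered aromatic ring of carbon only enters, and the shared core is otherwise untouched.

Going by the values given here, the step that is expected from this change in this assay is a 2.1-fold lower number from compound 2 to compound 4 (0.33 log units; beyond the scatter), downward and beyond the scatter, though with no measured pair to lean on its size is uncertain. Compound 4 is estimated at 1800 nM, with a range from 700 nM to 4500 nM.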

Compound 4, solubility: 15400 nM
Compound 4: middle estimate off by 8.6-fold (0.93 log units), on the low side; the whole stated range lies below it.
By their numbers in this assay, from the lowest: compound 2; then compounds 3, 1 and 4 (each within the scatter of the next).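

In this assay, going by these compounds alone, this is the first step that can be read at the saturated chain carbon bound to an aromatic carbon and a double-bonded chain carbon: phenyl in place of cyclopropyl gives a 4.0-fold higher number from compound 2 to compound 4 (0.60 log units; beyond the scatter) on an otherwise untouched shared core. The earlier compounds shown here could not show this, since no two of them differed in one place only, and the step shows that the number responds to the group on this carbon and that, for this pair, the six-membered aromatic ring of carbon only stands on the higher side of the three-membered non-aromatic ring of carbon only. No measured evidence is at hand that bears on why the number moves this way.

This single pair changes ring size, heavy-atom count and aromatic character together, so it leaves open which of these goes with the step, and cyclohexyl or a phenyl carrying an amine at the same carbon would begin to separate them. It also leaves open whether the same exchange would give a step of like direction and size on the core of compound 1 or the core of compound 3.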